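A Benzothiazole Swap on the Benzoxazole Thioether Series

This account rests on a few compounds, and the source may have more. Where it says the series, first, only, none or still open, it means among the compounds named here.

Compound 1 `Cn1c(-c2ccc(NC(=O)CSc3nc4ccccc4o3)cc2)nc(-c2ccccc2)c1-c1ccccc1` gives 11.2 ug/mL in a functional assay on MCF7 cells (Homo sapiens) for cytotoxicity, read by MTT assay, with a stated time of 24 h; a lower number here means a stronger inhibitor, a higher number a weaker inhibitor. Compound 2 `Cc1ccc2oc(SCC(=O)Nc3ccc(-c4nc(-c5ccccc5)c(-c5ccccc5)n4C)cc3)nc2c1` gives 22.4 ug/mL, and the step of a 2.0-fold higher number from compound 1 to compound 2 (0.30 log units; within the scatter) leaves the two numbers within the usual scatter of each other. Compound 3 `Cn1c(-c2ccc(NC(=O)CSc3nc4ccccc4s3)cc2)nc(-c2ccccc2)c1-c1ccccc1` differs from compound 2 by 1,3-benzothiazol-2-yl in place of 5-methyl-1,3-benzoxazol-2-yl on a sulfur. Among the measured compounds shown here, no measured step covers this exchange; the only step, from compound 1 to compound 2, was small. Compound 3 is therefore expected to show no shift beyond the scatter, a 1.6-fold lower number from compound 2 to compound 3 (0.20 log units; within the scatter). For compound 3 the estimate is 14 ug/mL, with a range from 6 ug/mL to 35 ug/mL.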

Compound 3, half-maximal inhibitory concentration: 15.8 ug/mL
Compound 3: middle estimate off by 1.1-fold (0.05 log units), on the low side; the measured number falls inside the stated range.
By their numbers in this assay, from the lowest: compounds 1, 3 and 2 (each within the scatter of the next).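

Among the compounds shown here, on a sulfur, 1,3-benzothiazol-2-yl in place of 1,3-benzoxazol-2-yl gives a 1.4-fold higher number from compound 1 to compound 3 (0.15 log units; within the scatter) in this assay, so this exchange of one ring atom alone, which the earlier compounds did not cover, leaves the number within the scatter. Replacing 5-methyl-1,3-benzoxazol-2-yl with the same group gives a 1.4-fold lower number from compound 2 to compound 3 (0.15 log units; within the scatter), so none of the three groups on this sulfur stands apart from the others. Nothing at hand explains these numbers. Going by these compounds, whether an amine or a carboxylic acid in place of these groups on the sulfur would move the number beyond the scatter remains open.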